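Swapping an aromatic ring for a propyl chain on the shared core

This account rests on a few compounds, and the source may have more. Where it says the series, first, only, none or still open, it means among the compounds named here.

Compound 3 `CC(=O)OC[C@H]1O[C@@H](n2cc(CN3C(=O)/C(=C/c4ccc(N(C)C)cc4)c4ccccc43)nn2)[C@H](OC(C)=O)[C@@H](OC(C)=O)[C@@H]1OC(C)=O` is the starting point of this comparison. In a functional assay on A549 cells (Homo sapiens) for cytotoxicity, read by sulforhodamine B assay, with a stated time of 48 h (on this read-out higher numbers stand for weaker inhibition and lower numbers for stronger inhibition), compound 3 gives 19400 nM, which is the higher of the two numbers that are known here. Its nearest neighbour is compound 2 `CC(=O)OC[C@H]1O[C@@H](n2cc(CN3C(=O)/C(=C\c4ccc(N(C)C)cc4)c4ccccc43)nn2)[C@H](OC(C)=O)[C@@H](OC(C)=O)[C@@H]1OC(C)=O`, which in this assay gives 17700 nM; the two values sit side by side, as a 1.1-fold higher number from compound 2 to compound 3 (0.04 log units; within the scatter) shows, and this is no surprise given (the fact that compounds 2 and 3 differ only in the configuration as drawn). Compound 1 `CC(=O)OC[C@H]1O[C@@H](n2cc(CN3C(=O)/C(=C/C=C/c4ccccc4)c4ccccc43)nn2)[C@H](OC(C)=O)[C@@H](OC(C)=O)[C@@H]1OC(C)=O` differs more: in this assay compound 1 reaches only a limit of > 100000 nM. The measured step of an at least 5.1-fold lower number from compound 1 to compound 3 (0.71 log units; beyond the scatter) shows that putting 4-(dimethylamino)phenyl where 2-phenylethenyl sat on that double-bonded chain carbon brought the number down by a clear margin.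

Compound 4 `CCC/C=C1/C(=O)N(Cc2cn([C@@H]3O[C@H](COC(C)=O)[C@@H](OC(C)=O)[C@H](OC(C)=O)[C@H]3OC(C)=O)nn2)c2ccccc21` changes the same position again: propyl in place of 4-(dimethylamino)phenyl on a double-bonded chain carbon bound to a double-bonded ring carbon. The ring and its single hydrogen-bond acceptor leave, and a short chain of three carbon atoms takes their place. Compound 1, lacking the dimethylamino-bearing ring, gave only a limit > 100000 nM, so the change to a bare propyl chain is expected to move the number upward rather than downward. The step from compound 3 is therefore estimated as a 3.1-fold higher number from compound 3 to compound 4 (0.49 log units; beyond the scatter), with a fair chance that the assay reports only a limit. For compound 4 in this assay the expected value is 60000 nM, within a range from 20000 nM to 200000 nM.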

Compound 4, half-maximal inhibitory concentration: 24100 nM
Compound 4: middle estimate off by 2.5-fold (0.40 log units), on the high side; the range from low to high includes it.
By their numbers in this assay, from the lowest: compounds 2, 3 and 4 (each within the scatter of the next). At a limit, above all of these: compound 1.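

Swapping 4-(dimethylamino)phenyl for propyl on a double-bonded chain carbon bound to a double-bonded ring carbon removes the aromatic ring and its hydrogen-bond acceptor, yet in this assay the reading holds, with a 1.2-fold higher number from compound 3 to compound 4 (0.09 log units; within the scatter). The ring that compound 1 lacks is therefore not needed for a measured number in this series, and a bare propyl chain serves as well as 4-(dimethylamino)phenyl. The clear step is instead an at least 4.1-fold lower number from compound 1 to compound 4 (0.61 log units; beyond the scatter), which ties the drop out of the measurable range to 2-phenylethenyl itself rather than to the absence of the dimethylamino-bearing ring, although this comparison rests on a limit and not on a number: the limit of > 100000 nM in this assay, at which 1 of the 4 values shown sits.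

The compounds shown leave open whether a shorter group such as methyl, a longer chain such as hexyl, or an amine at the end of the propyl chain would move the number beyond the scatter at this position. From the compounds shown here alone, it also remains open whether the other double-bond configuration of compound 4 would read as closely to it as compound 2 does to compound 3.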